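The compounds below may be only part of what the source reports. "The series", "measured", "known", "first", "only" and "open" are said of these compounds alone.

In a functional assay on MCF7 cells (Homo sapiens) for antiproliferative activity, read by MTT assay, with a stated time of 48 h (on this read-out higher numbers stand for weaker inhibition and lower numbers for stronger inhibition), two compounds have been measured:

Compound 1 (`CCn1c(C(=O)NCCN(C)C)ccc1C(CC)(CC)c1ccc(OCCC(O)(CC)CC)c(C)c1`): 430 nM
Compound 2 (`CCn1c(C(=O)N(CCC#N)CCC#N)ccc1C(CC)(CC)c1ccc(OCCC(O)(CC)CC)c(C)c1`): > 50000 nM

Among the compounds with values here, compound 1 at 430 nM holds the only actual number in this assay so far. Compound 2 reads > 50000 nM here, which is a limit of the assay and not a number.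

Compound 3 (`C#CC(C)OC(=O)c1ccc(C(CC)(CC)c2ccc(OCCC(O)(CC)CC)c(C)c2)n1CC`) has not yet been measured. Its change from compound 1 is (1-methylprop-2-yn-1-yl)oxy in place of (2-(dimethylamino)ethyl)amino on a carbonyl carbon with (1-methylprop-2-yn-1-yl)oxy in place of (2-(dimethylamino)ethyl)amino on a carbonyl carbon. Within the data shown here, the one measured step that bears on this replaces the same group and is large (an at least 110-fold higher number from compound 1 to compound 2 (2.06 log units; beyond the scatter)) and it ends at a limit (the limit of > 50000 nM in this assay, at which 1 of the 2 values shown sits), so a large move toward weaker inhibition is expected. The estimated step is a 12-fold higher number from compound 1 to compound 3 (1.07 log units; beyond the scatter) on this single precedent. Compound 3 is expected at 5000 nM (estimated range 800 nM to 40000 nM).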

Compound 3, half-maximal inhibitory concentration: > 50000 nM
Compound 3: only a limit was reported; the forecaster's own chance of this, stated with the estimate: 30%; middle value at least 10-fold (1.00 log units) away from the limit.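

With compound 3, a second replacement of the (2-(dimethylamino)ethyl)amino group on this carbonyl carbon ends the same way: in this assay, (1-methylprop-2-yn-1-yl)oxy in its place gives an at least 110-fold higher number from compound 1 to compound 3 (2.06 log units; beyond the scatter). The group entering in compound 2 has more heavy atoms than the one that leaves and the group entering in compound 3 has fewer, so heavy-atom count in one direction does not account for both steps. Compound 2 and compound 3 each read as a limit and not a number, and the step between them cannot be read: the limit of > 50000 nM in this assay, at which 2 of the 3 values shown sit.

The compounds shown leave open which part of the leaving group compound 1 needs to reach 430 nM, the amide hydrogen or the dimethylamino group. A (2-hydroxyethyl)amino group, or a longer chain ending in the same amine, would separate the two.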